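Saturating One Side-Chain Alkene on a Second Core

A few compounds are considered here, and "the series" means these few. Any claim that something is new, unique, unknown or untested is made for them only; others in the source may bear on it.

Of the compounds shown here, three have been measured in a functional assay on MDA-MB-231 cells (Homo sapiens) for antiproliferative activity, read by MTT assay; a higher number here means a weaker inhibitor, a lower number a stronger inhibitor. Compound 1 `CCCCC/C=C\C/C=C\CCCCCCCc1cc(=O)c2c(O)cc(O)c(C)c2o1` gives 6790 nM in this assay. Compound 3 `CC/C=C\C/C=C\C/C=C\CCCCCCCc1cc(=O)c2c(O)cc(O)c(C)c2o1` gives 6790 nM in this assay. Compound 2 `CC/C=C\C/C=C\C/C=C\CCCCCCCC1(O)CC(=O)c2c(O)cc(O)cc2O1` gives 6790 nM in this assay, level with compounds 1 and 3. Compound 4 `CCCCC/C=C\C/C=C\CCCCCCCC1(O)CC(=O)c2c(O)cc(O)cc2O1` awaits measurement in this assay.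

Compounds 3 and 1 differ in one place: butyl in place of but-1-en-1-yl on a saturated chain carbon bound to a double-bonded chain carbon. The step was no change at the digits printed from compound 3 to compound 1 (within the scatter). Compounds 2 and 4 differ by the same change, at the same place: butyl in place of but-1-en-1-yl on a saturated chain carbon bound to a double-bonded chain carbon. The two cores of compounds 2 and 3 differ as well, and that difference between the cores is not broken down here; their values show no gap in this assay.

With one occurrence of the change on record, the expectation for compound 4 is a step of no change at the digits printed from compound 2 to compound 4 (within the scatter) in this assay, resting on the step of no change at the digits printed from compound 3 to compound 1 (within the scatter) and on compound 2 standing at 6790 nM. Compound 4 is thus estimated at 6790 nM in this assay, with a plausible span from 3400 nM to 13600 nM.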

Compound 4, half-maximal inhibitory concentration: 6790 nM
For compound 4 middle estimate and measured number coincide at the digits printed, and the stated range covers the measured number.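

In this assay, the step for butyl in place of but-1-en-1-yl on a saturated chain carbon bound to a double-bonded chain carbon reads no change at the digits printed from compound 2 to compound 4 (within the scatter), and the two occurrences of this change agree across the two cores: the same change on two cores in this assay, no change at the digits printed (within the scatter) from compound 3 to compound 1 and no change at the digits printed (within the scatter) from compound 2 to compound 4, 1.0-fold (0.00 log units) apart, within the scatter of two such steps

Within these four compounds, saturating this one side-chain alkene therefore leaves the read-out flat on both cores. Within the data shown here, that agreement rests on only two pairs, both without a measurable step, so it does not show how a change that does move the value would carry from one core to the other, and it supports no rule for a third core or for another assay.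

The compounds shown leave open whether a fully saturated chain, a shorter chain, or a chain carrying an amine or a carboxylic acid would depart from this shared level. The separate contributions of the differences between the two cores also remain unresolved.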